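The source may report more compounds than this note shows. Statements on the series, on what has been measured and on what is new or still open speak of the compounds shown alone.

Measured compounds:
- compound 1, `N#C/N=C1\N(CCCCCCOc2ccc(Cl)cc2)C(=O)CN1c1ccncc1`: 443 nM
- compound 2, `CCC1C(=O)N(CCCCCCOc2ccc(Cl)cc2)/C(=N\C#N)N1c1ccncc1`: 6910 nM

In a functional assay on MCF7 cells (Homo sapiens) for cytotoxicity (on this read-out higher numbers stand for weaker inhibition and lower numbers for stronger inhibition), compound 2 stands at the highest number of the two; its nearest neighbour is compound 1, reached by a 16-fold higher number from compound 1 to compound 2 (1.19 log units; beyond the scatter), so compound 2 gives the weaker inhibition of the pair.

Compound 3, `N#C/N=C1\N(CCCCCCOc2ccc(Cl)cc2)C(=O)C(c2ccccc2)N1c1ccncc1`, has not yet been measured. It differs from compound 2 by phenyl in place of ethyl on a saturated ring carbon. Among the measured compounds shown here, only one measured step touches this position: the one from hydrogen to ethyl, a 16-fold higher number from compound 1 to compound 2 (1.19 log units; beyond the scatter), which was large and went towards weaker inhibition. Nothing measured tells how a phenyl compares with an ethyl there. For the measured compounds named here, the one step available suggests the position does not tolerate added bulk well, but whether a phenyl goes further in that direction, or sits where ethyl does, cannot be read from these two compounds.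

The expectation for compound 3 is therefore a number near that of compound 2, with a wide range on both sides; the estimated step is a 1.0-fold higher number from compound 2 to compound 3 (0.01 log units; within the scatter). The expected value for compound 3 is 7000 nM, with a range from 1500 nM to 30000 nM.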

Compound 3, half-maximal inhibitory concentration: 1130 nM
Estimate against measurement, compound 3: 6.2-fold (0.79 log units) above; the whole stated range lies above it.
By their numbers in this assay, from the lowest: compound 1; then compound 3; then compound 2.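

Working notes on the saturated ring carbon, next to the ring nitrogen: in this assay this position does not simply lose more as the group gains heavy atoms, since phenyl, the larger group, gives a 6.1-fold lower number from compound 2 to compound 3 (0.79 log units; beyond the scatter). Phenyl does not recover everything, however: against hydrogen it still gives a 2.6-fold higher number from compound 1 to compound 3 (0.41 log units; beyond the scatter), so compound 1 keeps the lowest number of the three, and the order at this carbon runs hydrogen, phenyl, ethyl rather than following group size. Nothing at hand accounts for the difference between ethyl and phenyl at this carbon.

Still open, on these data alone, is whether the gain over ethyl belongs to the aromatic ring itself, which a cyclohexyl group, with a saturated ring of the same size, or a benzyl group, with one carbon between ring and core, would help to separate. Also open, as far as these compounds go, is whether any group on this carbon, such as methyl, a hydroxyl, an amine or a phenyl ring carrying chlorine, can match or improve on the plain hydrogen of compound 1.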